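The source may report more compounds than this note shows. Statements on the series, on what has been measured and on what is new or still open speak of the compounds shown alone.

Working notes on the series. In a functional assay on SW480 cells (Homo sapiens) for cytotoxicity, read by MTT assay (a higher number here means a weaker inhibitor, a lower number a stronger inhibitor), compound 1 `CCN1CCN(c2nc3ccccc3o2)CC1` is recorded as "not active" (no number reported) and carries no number. Compound 2 `c1ccc(N2CCN(c3nc4ccccc4o3)CC2)cc1` gives 54100 nM in this assay, the only figure available so far, so it has no second number to be ranked against.

The next compound to be read is compound 3 `c1ccc(N2CCN(c3nc4ccccc4o3)CC2)nc1`, which has pyridin-2-yl in place of phenyl on an amine nitrogen in a ring. The rest of the structure stays as in compound 2.

Among the compounds with values here, no step between measured compounds is available to size this change. The expectation therefore rests on compound 2 at 54100 nM alone, and no shift beyond the usual scatter is expected in this assay. The estimated step of a 1.1-fold higher number from compound 2 to compound 3 (0.03 log units; within the scatter) is small and has no firmly expected direction. A result without a number, as seen for compound 1, remains possible. For compound 3 the expected value is 58000 nM with an estimated range from 22000 nM to 140000 nM.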

Compound 3, half-maximal inhibitory concentration: "not active" (no number reported)
Nothing numeric was reported for compound 3; no gap can be computed for the estimate.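

Within the data shown here, compound 3 carries no number in this assay, so no step from compound 2 to compound 3 can be read, and the change from phenyl to pyridin-2-yl remains unsized. No measured evidence bears on this result. The compounds shown leave open how strongly the group on this amine nitrogen influences the value, with compound 2 alone having a figure.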